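A few compounds are considered here, and "the series" means these few. Any claim that something is new, unique, unknown or untested is made for them only; others in the source may bear on it.

Compound 1, `ClCc1ccc(Cn2cnc3c(Cl)nc(Cl)nc32)cc1`: > 100000 nM
Compound 2, `ClCc1ccccc1Cn1cnc2c(Cl)nc(Cl)nc21`: "not determined" (no result reported)
Compound 3, `ClCc1ccc(Cn2cnc3ncnc(Cl)c32)cc1`: 3800 nM

Going by the values given here, in a functional assay on COLO 205 cells (Homo sapiens) for cytotoxicity, read by sulforhodamine B assay, with a stated time of 48 h (on this read-out higher numbers stand for weaker inhibition of growth and lower numbers for stronger inhibition of growth), compound 3 gives 3800 nM, the only number among the three entries. Compound 1 reaches only a limit of this assay, > 100000 nM, and for compound 2 no result is reported. The next compound, compound 4 `ClCc1ccc(Cn2cnc3nc(Cl)nc(Cl)c32)cc1`, differs from compound 3 by one change: chloro in place of hydrogen on an aromatic carbon. Among the compounds with values here, no step between measured compounds is available to gauge this change. Compound 3 is expected to move by a 1.6-fold higher number from compound 3 to compound 4 (0.20 log units; within the scatter), a step not clearly beyond the scatter, perhaps toward weaker growth inhibition. Compound 4 is therefore estimated at 6000 nM, within a range from 1500 nM to 30000 nM.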

Compound 4, concentration for total growth inhibition: > 100000 nM
Compound 4 gave a limit, no number; the forecaster's own chance of this, stated with the estimate: 15%; middle value at least 16-fold (1.22 log units) away from the limit.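

In this assay, going by these compounds alone, the step at this position is the first one available, and it is large: chloro in place of hydrogen on an aromatic carbon, between two ring nitrogen atoms, gives an at least 26-fold higher number from compound 3 to compound 4 (1.42 log units; beyond the scatter). The change is therefore far from neutral, and growth inhibition is weakened beyond the scatter. The value of compound 4 is a limit, so the step gives only a minimum size: the limit of > 100000 nM in this assay, at which 2 of the 4 values shown sit.

The compounds shown leave open whether an amine, a methoxy group or a longer chain at this position would behave like the hydrogen of compound 3 or like the chloro group of compound 4.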